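The source may hold more compounds than are shown below. What is called first, only, known or untested is meant among the compounds shown, and "the series" means these compounds.

Among the compounds with values here, in a functional assay on K562 cells (Homo sapiens) for inhibition, read by trypan blue exclusion, with a stated time of 72 h (a lower number here means a stronger inhibitor, a higher number a weaker inhibitor), three related compounds have numbers so far. Compound 1 (`Cn1c(=O)c(S(=O)(=O)c2ccc(F)cc2)cc2cnc(Nc3ccc4occc4c3)nc21`) gives 5000 nM as the lowest of the three. Compound 3 (`Cn1c(=O)c(S(=O)(=O)c2ccc(F)cc2F)cc2cnc(Nc3ccc4occc4c3)nc21`) gives 15000 nM and compound 2 (`Cn1c(=O)c(S(=O)(=O)c2ccccc2)cc2cnc(Nc3ccc4ncccc4c3)nc21`) gives 100000 nM as the highest.

The next molecule, compound 4 (`Cn1c(=O)c(S(=O)(=O)c2ccc(F)cc2)cc2cnc(Nc3ccc4[nH]ncc4c3)nc21`), keeps the core of compound 1 and alters one group (1H-indazol-5-yl in place of 1-benzofuran-5-yl on a nitrogen on an aromatic ring). In short, 1H-indazol-5-yl stands in place of 1-benzofuran-5-yl on a nitrogen on an aromatic ring.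

Within the data shown here, the only measured single change is a 3.0-fold higher number from compound 1 to compound 3 (0.48 log units; beyond the scatter) and it is a different edit, fluoro in place of hydrogen on an aromatic carbon. Among the measured compounds shown here, it therefore says little about this swap, and no measured step tests this group directly. The high number of compound 2 (100000 nM) does show how far values reach in this small set, so the range should be wide and lean upward.

The expected change is small (a 1.6-fold higher number from compound 1 to compound 4 (0.20 log units; within the scatter)) and is not expected to clearly exceed the scatter. The estimate for compound 4 is 8000 nM with an expected range from 1500 nM to 40000 nM in this test.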

Compound 4, half-maximal inhibitory concentration: 10000 nM
For compound 4 the middle estimate is 1.3-fold (0.10 log units) below the measured one; measured number inside the range.
By their numbers in this assay, from the lowest: compounds 1, 4 and 3 (each within the scatter of the next, the first and the last beyond it); then compound 2.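

In this assay, the step from the 1-benzofuran-5-yl group to the 1H-indazol-5-yl group on the aromatic amine nitrogen is a 2.0-fold higher number from compound 1 to compound 4 (0.30 log units; within the scatter), so this assay does not separate the two compounds. Within the data shown here, this is the first direct test at this position, and it shows that replacing the ring oxygen-containing bicycle with one that has two ring nitrogens and a hydrogen-bond donor leaves the number within the scatter. No measurement shown here offers an explanation for this result.

As far as these compounds go, it remains open whether a simpler group on that nitrogen, such as a phenyl ring carrying an amine or a carboxylic acid, would also stay in this range. From the compounds shown here alone, it is also open whether the added fluoro, which gave a 3.0-fold higher number from compound 1 to compound 3 (0.48 log units; beyond the scatter), would have a similar effect on compound 4.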